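Fluoro for Methyl Across Two Related Cores

The compounds below may be only part of what the source reports. "The series", "measured", "known", "first", "only" and "open" are said of these compounds alone.

Compound 1 `COc1cc2c(Oc3ccc(NC(=O)c4cc(-c5ccc(C)cc5)ccn4)cc3F)ccnc2cc1OCCCN1CCCC1`: 560 nM
Compound 2 `COc1cc2c(Oc3ccc(NC(=O)c4cc(-c5ccc(F)cc5)ccn4)cc3F)ccnc2cc1OCCCN1CCCC1`: 1780 nM

Compounds 1 and 2 share one core and differ in a single place: fluoro in place of methyl on an aromatic carbon. In a functional assay on U-87MG ATCC cells (Homo sapiens) for cytotoxicity, read by MTT assay, with a stated time of 72 h (on this read-out higher numbers stand for weaker inhibition and lower numbers for stronger inhibition), compound 1 gives 560 nM, and the change brings a 3.2-fold higher number from compound 1 to compound 2 (0.50 log units; beyond the scatter). Compound 3 `COc1cc2c(Oc3ccc(NC(=O)c4nccc(-c5ccc(C)cc5)n4)cc3F)ccnc2cc1OCCCN1CCCC1` carries a different core; the difference between the two cores is not broken down here, and in this assay compound 3 gives "not determined" (no result reported), so no single number for compound 3 exists. Compound 4 `COc1cc2c(Oc3ccc(NC(=O)c4nccc(-c5ccc(F)cc5)n4)cc3F)ccnc2cc1OCCCN1CCCC1` arises from compound 3 by the same change, (fluoro in place of methyl on an aromatic carbon), at the same place. Compound 3 has no value, so the expectation for compound 4 rests on compound 1 at 560 nM and the step of a 3.2-fold higher number from compound 1 to compound 2 (0.50 log units; beyond the scatter), taken to carry over to the new core with wide uncertainty. Compound 4 is expected to give 1800 nM, estimated to lie between 500 nM and 7000 nM.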

Compound 4, half-maximal inhibitory concentration: 1130 nM
The estimate for compound 4 lay 1.6-fold (0.20 log units) above the measured number, within the range that was stated.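

Compound 3 has no number in this assay, so the step from compound 3 to compound 4 cannot be read. Whether fluoro in place of methyl does the same on this core as on the core of compound 1 stays open, and no data shown here explain the values.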